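The compounds below may be only part of what the source reports. "The series", "measured", "known", "first", "only" and "open" are said of these compounds alone.

In a functional assay on the whole organism for inhibition, with Cavia porcellus as the target (on this read-out lower numbers stand for an effect already at smaller amounts and higher numbers for an effect only at larger amounts of compound), three compounds sharing one core have been measured. Compound 1 `COc1ccccc1OCC1SCCN1C(=O)CN` gives 57 mg/kg, compound 2 `COc1ccccc1OCC1SCCN1C(C)=O` gives 46 mg/kg, and compound 3 `CNC(=O)CC(=O)N1CCSC1COc1ccccc1OC` gives 21 mg/kg, the lowest of the three numbers.

The next structure, compound 4 `COc1ccccc1OCC1SCCN1C(=O)CC(=O)N1CCN(C)CC1`, differs from compound 3 in one place: 4-methylpiperazin-1-yl in place of methylamino on a carbonyl carbon. Put simply, 4-methylpiperazin-1-yl stands in place of methylamino on a carbonyl carbon. Within the data shown here, no measured step makes this exact swap, so the nearest guides are the changes on a saturated chain carbon bound to a carbonyl carbon. Hydrogen in place of amino gave a 1.2-fold lower number from compound 1 to compound 2 (0.09 log units; within the scatter). Methylcarbamoyl, the group now being altered, gave a 2.2-fold lower number from compound 2 to compound 3 (0.34 log units; beyond the scatter) in place of hydrogen and a 2.7-fold lower number from compound 1 to compound 3 (0.43 log units; beyond the scatter) in place of amino.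

All of these steps are small, so no large move is expected in this assay. With compound 3 already lowest, a slight drift to a higher number seems more likely than a further fall, probably no more than the scatter. The expected size of the change is a 1.3-fold higher number from compound 3 to compound 4 (0.12 log units; within the scatter). Compound 4 is estimated at 28 mg/kg, with an expected range from 11 mg/kg to 70 mg/kg.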

Compound 4, dose for half-maximal effect: 27 mg/kg
For compound 4 the middle estimate is 1.0-fold (0.02 log units) above the measured one; the range from low to high includes it.
By their numbers in this assay, from the lowest: compounds 3, 4, 2 and 1 (each within the scatter of the next, the first and the last beyond it).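

In this assay, the carbonyl carbon accepts 4-methylpiperazin-1-yl, with 7 heavy atoms and a six-membered ring but no hydrogen-bond donor, in place of methylamino, with 2 heavy atoms and one donor: a 1.3-fold higher number from compound 3 to compound 4 (0.11 log units; within the scatter) is the whole effect of this swap. Cut one bond further out, the change reads differently against the two simpler compounds, since a 1.7-fold lower number from compound 2 to compound 4 (0.23 log units; within the scatter) is the result of (4-methylpiperazin-1-yl)carbonyl in place of hydrogen, while a 2.1-fold lower number from compound 1 to compound 4 (0.32 log units; beyond the scatter) is its result in place of amino. Nothing available explains these numbers.

As far as these compounds go, it remains open whether a morpholine ring or a simple dimethylamino group on this carbonyl carbon would fit the same picture. A carboxylic acid there is also an untested case among the compounds shown.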